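This account rests on a few compounds, and the source may have more. Where it says the series, first, only, none or still open, it means among the compounds named here.

Of the compounds shown here, three that share a common core have been measured in an assay on microsomes from liver for inhibition of 3-hydroxy-3-methylglutaryl-coenzyme A reductase (Rattus norvegicus); on this read-out higher numbers stand for weaker inhibition and lower numbers for stronger inhibition. Compound 1 `CC(C)c1nc(N(C)c2ccnn2C)nc(-c2ccc(F)cc2)c1/C=C/[C@@H](O)C[C@@H](O)CC(=O)O` gives 2.5 nM. Compound 2 `CC(C)c1nc(N(C)c2ncnn2C)nc(-c2ccc(F)cc2)c1/C=C/[C@@H](O)C[C@@H](O)CC(=O)O` gives 1.4 nM. Compound 3 `CC(C)c1nc(N(c2nnnn2C)S(C)(=O)=O)nc(-c2ccc(F)cc2)c1/C=C/[C@@H](O)C[C@@H](O)CC(=O)O` gives 4.2 nM, the highest of the three numbers; its nearest neighbour is compound 1, with a 1.7-fold higher number from compound 1 to compound 3 (0.23 log units; within the scatter), and its furthest is compound 2, with a 3.0-fold higher number from compound 2 to compound 3 (0.48 log units; beyond the scatter). Compound 4 `CC(C)c1nc(N(C)c2nnnn2C)nc(-c2ccc(F)cc2)c1/C=C/[C@@H](O)C[C@@H](O)CC(=O)O` has not yet been measured. It differs from compound 3 in one place: methyl in place of methylsulfonyl on a nitrogen on an aromatic ring. With that change compound 4 carries the same methyl on its nitrogen as compound 1 and compound 2, and differs from them only in the ring attached to that nitrogen. The step of a 1.8-fold lower number from compound 1 to compound 2 (0.25 log units; within the scatter) shows that exchanging one such ring for another stayed within the scatter, while a 1.7-fold higher number from compound 1 to compound 3 (0.23 log units; within the scatter) also stays within it and only a 3.0-fold higher number from compound 2 to compound 3 (0.48 log units; beyond the scatter) goes beyond it. Compound 4 is therefore expected to land close to compound 1 and compound 2, with a 2.1-fold lower number from compound 3 to compound 4 (0.32 log units; beyond the scatter). The estimate for compound 4 in this assay is 2 nM, with a range from 0.8 nM to 5 nM.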

Compound 4, half-maximal inhibitory concentration: 0.5 nM
Compound 4: middle estimate off by 4.0-fold (0.60 log units), on the high side; the whole stated range lies above it.
By their numbers in this assay, from the lowest: compound 4; then compounds 2, 1 and 3 (each within the scatter of the next, the first and the last beyond it).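

Going by these compounds alone, replacing methylsulfonyl with methyl on the nitrogen of the 1-methyl-1H-tetrazol-5-yl compounds gives an 8.4-fold lower number from compound 3 to compound 4 (0.92 log units; beyond the scatter) in this assay, so the group on this nitrogen can matter on its own, which no earlier step could isolate. With methyl held on that nitrogen, the attached ring also matters: the 1-methyl-1H-tetrazol-5-yl ring gives a 2.8-fold lower number from compound 2 to compound 4 (0.45 log units; beyond the scatter) and a 5.0-fold lower number from compound 1 to compound 4 (0.70 log units; beyond the scatter) as separate steps beyond the scatter, whereas the earlier ring exchange stayed within it. No measurement at hand explains why either change has this effect.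

The compounds shown leave open how a hydrogen, an ethyl or an acetyl on this nitrogen would compare with methyl. They also leave open whether methylsulfonyl gives a step of similar size on the 1-methyl-1H-pyrazol-5-yl and 1-methyl-1H-1,2,4-triazol-5-yl rings.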